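A few compounds are considered here, and "the series" means these few. Any claim that something is new, unique, unknown or untested is made for them only; others in the source may bear on it.

Measured in a functional assay, read by spectrophotometry; a lower number here means that less compound is needed, a higher number that more compound is needed for the effect:
- Compound 1 `COc1ccc(-c2cc(=O)c3ccc(O)cc3o2)cc1OC`: 22.4 nM
- Compound 2 `COc1cc(-c2cc(=O)c3ccc(O)cc3o2)cc(OC)c1OC`: 26.4 nM

Going by the values given here, the one measured step, a 1.2-fold higher number from compound 1 to compound 2 (0.07 log units; within the scatter), lies within the scatter, so compound 2 stands level with compound 1 in this assay. Compound 3 `COc1cc(-c2cc(=O)c3ccc(OCCCN4CCC(C)CC4)cc3o2)cc(OC)c1OC` has yet to be measured. It differs from compound 2 at a single place: 3-(4-methylpiperidin-1-yl)propyl in place of hydrogen on an oxygen on an aromatic ring. Put simply, hydroxy gives way to 3-(4-methylpiperidin-1-yl)propoxy.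

The measured step, methoxy in place of hydrogen on an aromatic carbon, is a different and much smaller change, so it offers only weak guidance. Among the compounds with values here, no measured compound carries a group like this one on that oxygen, which leaves the direction open and the range wide. The expected step is therefore none beyond the scatter: a 1.1-fold higher number from compound 2 to compound 3 (0.06 log units; within the scatter). Compound 3 is estimated at 30 nM, with an expected range of 5 nM to 200 nM.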

Compound 3, half-maximal effective concentration: 26.8 nM
Estimate against measurement, compound 3: 1.1-fold (0.05 log units) above, within the range that was stated.
By their numbers in this assay, from the lowest: compounds 1, 2 and 3 (each within the scatter of the next).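

In this assay, 3-(4-methylpiperidin-1-yl)propyl in place of hydrogen on this oxygen gives a 1.0-fold higher number from compound 2 to compound 3 (0.01 log units; within the scatter) and so leaves the two compounds level. The earlier step covered only a small methoxy on an aromatic carbon, whereas this one shows that a far larger group with a six-membered non-aromatic ring can sit on the oxygen with no shift beyond the scatter. It also shows that the free hydroxy of compound 2 is not needed to keep the number in this range, though no supporting data explain this result.

From the compounds shown here alone, how a shorter or longer chain on this oxygen would read remains open, as does a morpholine ring or a dimethylamine in place of the 4-methylpiperidine. A carboxylic acid at the end of the chain is equally untested among the compounds shown here.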